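A 4-nitrobenzyl Swap on a Compound Without a Number

The source may hold more compounds than are shown below. What is called first, only, known or untested is meant among the compounds shown, and "the series" means these compounds.

Compound 1 `COc1ccc(-n2cc(COc3ccc(/C=C/C(=O)c4cc5c(cc4O)OC(C)(C)CC5)cc3)nn2)c([N+](=O)[O-])c1` offers no figure to start from: in a functional assay on HepG2 cells (Homo sapiens) for antiproliferative activity, read by MTT assay (on this read-out higher numbers stand for weaker inhibition and lower numbers for stronger inhibition), compound 1 is reported as "not active" (no number reported) and no concentration is given. Among the measured compounds shown here, the only number in this small set comes from compound 2 `Cc1c(-n2cc(COc3ccc(/C=C/C(=O)c4ccc5c(c4O)CCC(C)(C)O5)cc3)nn2)cccc1[N+](=O)[O-]`, where compound 2 gives 115000 nM in this assay on the same read-out.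

Compound 3 `CC1(C)CCc2cc(C(=O)/C=C/c3ccc(OCc4cn(Cc5ccc([N+](=O)[O-])cc5)nn4)cc3)c(O)cc2O1` keeps the core of compound 1 and differs in one place (4-nitrobenzyl in place of 4-methoxy-2-nitrophenyl on an aromatic nitrogen): 4-nitrobenzyl in place of 4-methoxy-2-nitrophenyl on an aromatic nitrogen. No measured step between any of these compounds is available, so the data do not show what such a change does in this assay. A modest step towards stronger inhibition is expected, enough to give a measurable number but not one far removed from compound 2, whose 115000 nM is the sole anchor. A second report of no activity also remains possible. For compound 3 the half-maximal inhibitory concentration is estimated at 60000 nM with 15000 nM to 200000 nM as the expected range.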

Compound 3, half-maximal inhibitory concentration: 109000 nM
The estimate for compound 3 lay 1.8-fold (0.26 log units) below the measured number; measured number inside the range.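

Among the compounds shown here, compound 1 is recorded only as "not active" (no number reported), so no step from compound 1 to compound 3 can be read. The compounds shown leave open what 4-nitrobenzyl in place of 4-methoxy-2-nitrophenyl does to inhibition in this assay on an otherwise shared core. No supporting evidence bears on this result.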